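Compound 3 and the formyl change

The source may hold more compounds than are shown below. What is called first, only, known or untested is meant among the compounds shown, and "the series" means these compounds.

In a functional assay on MV4-11 cells (Homo sapiens) for inhibition, read by resazurin assay, with a stated time of 72 h (on this read-out lower numbers stand for stronger inhibition of growth and higher numbers for weaker inhibition of growth), compound 3 `Cc1csc(-c2cncc(Cl)c2N2CCC3(CCNC3=O)CC2)c1` gives 650 nM, and compound 1 `O=C1NCCC12CCN(c1c(Cl)cncc1-c1ccco1)CC2` gives 940 nM. The two sit within the scatter of each other: a 1.4-fold lower number from compound 1 to compound 3 (0.16 log units; within the scatter). Compound 2 `Cc1ccc(-c2cncc(Cl)c2N2CCC3(CCNC3=O)CC2)o1` stands apart at 4950 nM, and a 7.6-fold lower number from compound 2 to compound 3 (0.88 log units; beyond the scatter) is beyond the scatter.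

Compound 4 `O=Cc1ccc(-c2cncc(Cl)c2N2CCC3(CCNC3=O)CC2)s1` has 5-formylthiophen-2-yl in place of 4-methylthiophen-2-yl on an aromatic carbon. Among the measured compounds shown here, no measured compound carries a formyl group, so any read-across is indirect.

For the measured compounds named here, two measured steps bear on this change. The exchange of furan-2-yl for 4-methylthiophen-2-yl in a 1.4-fold lower number from compound 1 to compound 3 (0.16 log units; within the scatter) gave no shift beyond the scatter, so moving between these ring types offers no clear guide. The 5-methylfuran-2-yl group of compound 2 is the nearest measured match to 5-formylthiophen-2-yl, and a 5.3-fold higher number from compound 1 to compound 2 (0.72 log units; beyond the scatter) is a modest rise beyond the scatter. That single example points to a higher number, though it involves methyl on a furan and not formyl on a thiophene.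

The expected step is a 2.5-fold higher number from compound 3 to compound 4 (0.39 log units; beyond the scatter), a modest rise whose direction is not secure.

For compound 4 the estimated value is 1600 nM, with an expected range from 450 nM to 5500 nM.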

Compound 4, concentration for 50% growth inhibition: 750 nM
For compound 4 the middle estimate is 2.1-fold (0.33 log units) above the measured one; low and high end bracket the measured number.
By their numbers in this assay, from the lowest: compounds 3, 4 and 1 (each within the scatter of the next); then compound 2.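

At this position, the 5-formylthiophen-2-yl group of compound 4 reads the same in this assay as the 4-methylthiophen-2-yl group, a 1.2-fold higher number from compound 3 to compound 4 (0.06 log units; within the scatter), and the unsubstituted furan-2-yl group, a 1.3-fold lower number from compound 1 to compound 4 (0.10 log units; within the scatter), so the added formyl carbonyl brings no shift that can be told from the scatter. Compound 2 remains the only one apart, a 6.6-fold lower number from compound 2 to compound 4 (0.82 log units; beyond the scatter), which shows that the 5-formylthiophen-2-yl group does not share the higher number seen with 5-methylfuran-2-yl, although these two groups differ in both the ring and its substituent. The data offer no explanation for this difference or for the flat reading among compounds 1, 3 and 4.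

Going by these compounds, whether the higher number of compound 2 goes with the methyl group or with the furan ring stays open, and a 5-methylthiophen-2-yl or a 5-formylfuran-2-yl group at this position would separate the two. Also open, on these data alone, is how far the flat reading extends, for instance to a carboxylic acid or an aminomethyl group in place of the formyl group.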